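The compounds below may be only part of what the source reports. "The series", "measured", "known", "first", "only" and "open" are said of these compounds alone.

Compound 1 `Nc1ccn([C@@H]2O[C@H](CO)[C@](O)(CO)[C@H]2O)c(=O)n1`: 12300 nM
Compound 2 `CNc1ccnc2c1ncn2[C@@H]1O[C@H](CO)[C@](O)(CN=[N+]=[N-])[C@H]1O`: > 100000 nM (a limit of the assay, not a number)

Among the compounds with values here, in an ADME assay on Huh-7 cells (Homo sapiens) for cytotoxicity, read by WST assay, with a stated time of 3 days (a higher number here means that more compound is tolerated, a lower number that less compound is tolerated), compound 1 gives the only actual number, 12300 nM. Compound 2, the other measured compound, reads > 100000 nM, which is a limit and not a number.

Compound 3 `[N-]=[N+]=NC[C@@]1(O)[C@@H](CO)O[C@@H](n2ccc(N)nc2=O)[C@@H]1O` has not yet been measured. It departs from compound 1 in one place: azido in place of hydroxy on a saturated chain carbon bound to a saturated ring carbon. Put another way, hydroxymethyl becomes azidomethyl. Within the data shown here, no measured pair isolates this change. Among the measured compounds shown here, the only hint is that compound 2 also carries azidomethyl and reaches the limit of > 100000 nM.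

A moderate move towards more compound tolerated is therefore expected, though with little certainty. The expected size is a 3.3-fold higher number from compound 1 to compound 3 (0.51 log units; beyond the scatter). For compound 3 the estimated value is 40000 nM, with an expected range of 10000 nM to 100000 nM.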

Compound 3, half-maximal cytotoxic concentration: 300 nM
Compound 3: the middle estimate sits 130-fold (2.12 log units) above what was measured, and the stated range ends above it.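

In this assay the change from hydroxymethyl to azidomethyl on the core of compound 1 gives a 41-fold lower number from compound 1 to compound 3 (1.61 log units; beyond the scatter) and so shows that this place, a saturated chain carbon bound to a saturated ring carbon, is sensitive to the swap, with far less compound tolerated once azido stands in place of hydroxy. Within the data shown here, this is the first direct reading of the change, since the earlier compounds offered no pair that isolated it. Compound 2 also carries azidomethyl, and its > 100000 nM is a limit of the assay and not a number.

Nothing measured here explains the size of this step. On these data alone, whether an amine, a methoxy group or a fluorine at the same place would behave like hydroxy or like azido remains open, as does whether the step holds on any other core.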